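The compounds below may be only part of what the source reports. "The series", "measured", "known", "first", "only" and "open" are said of these compounds alone.

Working notes on the series.

Compound 1 `CCOC(=O)CCCCCOc1cccc(CN(C(=O)c2ccc(-c3cccc(Oc4ccccc4)c3)cc2)C(C)C)c1` and compound 2 `CCOC(=O)CCCCCOc1cccc(CN(C(=O)c2ccc(-c3ccc4c(c3)OCCO4)cc2)C(C)C)c1` have both been run in an ADME assay on HepG2 cells (Homo sapiens) for cytotoxicity, read by CellTiter-Glo and resazurin assay, with a stated time of 72 h; a lower number here means that less compound is needed, a higher number that more compound is needed for the effect. In this assay compound 1 returns only a limit, > 26000 nM. In this assay compound 2 likewise returns only a limit, > 24400 nM. Compound 2 therefore stands at the limit of > 24400 nM in this assay, at which 1 of the 2 values shown sits, and the other measured compound sits at the limit of > 26000 nM in this assay, at which 1 of the 2 values shown sits, so no number is known for either.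

The next compound is compound 3 `CCOC(=O)CCCCCOc1cccc(CN(C(=O)c2ccc(-c3cccc(CC(=O)O)c3)cc2)C(C)C)c1`, which differs from compound 2 in one place: 3-(carboxymethyl)phenyl in place of 2,3-dihydro-1,4-benzodioxin-6-yl on an aromatic carbon.

Among the measured compounds shown here, no step between measured compounds is available, so the expectation for compound 3 rests on compound 2 alone. Since compound 2 gave only the limit > 24400 nM, the step that the limit leaves unreadable from compound 2 to compound 3 is expected to be none beyond the scatter, with compound 3 most likely again reported as a limit. For compound 3 in this assay the estimate is 25000 nM, within 12000 nM to 50000 nM.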

Compound 3, half-maximal effective concentration: > 26000 nM
Compound 3: a limit, no number; the forecaster's own chance of this, stated with the estimate: 80%; middle value at least 1.0-fold (0.01 log units) from the limit.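

Among the compounds shown here, compound 1, compound 2 and compound 3 all return only limits in this assay, so no step among them can be read. The compounds shown leave open the concentration at which any of the three reaches the half-maximal effect, and whether the exchanged groups shift it at all.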